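From Propylsulfanyl to Benzylsulfanyl: What to Expect of Compound 4

This account rests on a few compounds, and the source may have more. Where it says the series, first, only, none or still open, it means among the compounds named here.

Of the compounds shown here, three sharing one core have been tested in a functional assay on MGC-803 cells (Homo sapiens) for antiproliferative activity, read by MTT assay, with a stated time of 72 h; on this read-out lower numbers stand for stronger inhibition and higher numbers for weaker inhibition. Compound 1 `C#CCSc1nc(N/N=C(\C)c2ccccc2O)c2nnn(Cc3ccccc3)c2n1` gives 3820 nM, compound 2 `CCCSc1nc(N/N=C(\C)c2ccccc2O)c2nnn(Cc3ccccc3)c2n1` gives 2310 nM, and compound 3 `CCCSc1nc(N/N=C(\C)c2ccccc2O)c2nnn(Cc3ccc(F)cc3)c2n1` gives 11000 nM. Compound 2 carries the lowest number of the three, though compound 1 sits within the scatter of it, with a 1.7-fold lower number from compound 1 to compound 2 (0.22 log units; within the scatter); only compound 3 stands clearly apart, with a 4.8-fold higher number from compound 2 to compound 3 (0.68 log units; beyond the scatter).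

Compound 4 `C/C(=N\Nc1nc(SCc2ccccc2)nc2c1nnn2Cc1ccccc1)c1ccccc1O` differs from compound 2 in one place: phenyl in place of ethyl on a saturated chain carbon bound to a sulfur. Read one bond further out, the propylsulfanyl of compound 2 becomes the benzylsulfanyl of compound 4.

Among the measured compounds shown here, only one measured step touches the same saturated chain carbon bound to a sulfur, the one from compound 1 to compound 2, and it stayed within the scatter. The step from compound 2 to compound 3 sits elsewhere on the molecule and does not inform this change. For the measured compounds named here, no measured pair shows ethyl set against phenyl at this position, so the direction is open. On this evidence the expected step in this assay is small, a 1.1-fold higher number from compound 2 to compound 4 (0.05 log units; within the scatter), with no confident direction.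

Compound 4 is therefore estimated at 2600 nM, most likely between 900 nM and 7500 nM.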

Compound 4, half-maximal inhibitory concentration: 850 nM
Compound 4: the middle estimate sits 3.1-fold (0.49 log units) above what was measured; measured number below the stated range.
By their numbers in this assay, from the lowest: compound 4; then compounds 2 and 1 (each within the scatter of the next); then compound 3.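

The earlier compounds had shown this saturated chain carbon bound to a sulfur only through a step within the scatter, so it could have seemed a place where changes count for little. Among the compounds shown here, compound 4 shows otherwise: phenyl in place of ethyl gives a 2.7-fold lower number from compound 2 to compound 4 (0.43 log units; beyond the scatter) in this assay and is the first step at this place to lie beyond the scatter. Phenyl in place of ethynyl gives a 4.5-fold lower number from compound 1 to compound 4 (0.65 log units; beyond the scatter) on the same read-out, so benzylsulfanyl stands apart from both of the smaller groups tested here, which themselves remain within the scatter of each other. Nothing at hand explains why the phenyl lowers the number.

For the compounds shown here, only one aromatic group has been seen at this place, so it remains open whether a longer chain such as butyl would give a similar step or whether the aromatic ring itself is what counts. Also open, going by these compounds, is how an amine or a carboxylic acid on that phenyl would read, and whether fluoro there would raise the number as it did in a 4.8-fold higher number from compound 2 to compound 3 (0.68 log units; beyond the scatter) on the other benzyl group.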